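The source may report more compounds than this note shows. Statements on the series, on what has been measured and on what is new or still open speak of the compounds shown alone.

Measured in an ADME assay on Vero cells (Chlorocebus sabaeus) for cytotoxicity, read by resazurin assay, with a stated time of 72 h; on this read-out lower numbers stand for stronger inhibition and higher numbers for weaker inhibition:
- compound 1 `O=C(CCN1CCN(c2ccc(C(F)(F)F)cc2)CC1)c1ccc(F)c(Br)c1`: 66800 nM
- compound 2 `O=C(CCN1CCN(c2ccc(Cl)cc2)CC1)c1ccc(F)c(Br)c1`: 206000 nM
- compound 3 `O=C(CCN1CCN(c2ccc([N+](=O)[O-])cc2)CC1)c1ccc(F)c(Br)c1`: 256000 nM

Two steps place compound 2 in this small set: a 3.1-fold higher number from compound 1 to compound 2 (0.49 log units; beyond the scatter), and a 1.2-fold higher number from compound 2 to compound 3 (0.09 log units; within the scatter). Compound 4 `O=C(CCN1CCN(c2ccc(Cl)cc2)CC1)c1ccc(Cl)c(F)c1` keeps the rest of compound 2 but carries 4-chloro-3-fluorophenyl in place of 3-bromo-4-fluorophenyl on a carbonyl carbon. For the measured compounds named here, no measured step touches this group, so the three steps bear on it only loosely, as a guide to size. The largest of them, a 3.8-fold higher number from compound 1 to compound 3 (0.58 log units; beyond the scatter), changed a different group and was still modest. No step beyond the scatter is therefore expected in this assay, in either direction, although a modest one remains possible. The expected result is a 1.0-fold lower number from compound 2 to compound 4 (0.01 log units; within the scatter). Compound 4 is estimated at 200000 nM, with an expected range of 90000 nM to 450000 nM.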

Compound 4, half-maximal inhibitory concentration: 175000 nM
Compound 4: middle estimate off by 1.1-fold (0.06 log units), on the high side; measured number inside the range.
By their numbers in this assay, from the lowest: compound 1; then compounds 4, 2 and 3 (each within the scatter of the next).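

For the compounds shown here, on this carbonyl carbon, the step to 4-chloro-3-fluorophenyl from 3-bromo-4-fluorophenyl gives a 1.2-fold lower number from compound 2 to compound 4 (0.07 log units; within the scatter) in this assay, the first look at this group. Here, one halogen-bearing phenyl can stand in for the other with no difference beyond the scatter, unlike the trifluoromethyl steps at the other end of the molecule. Nothing available explains this result. Still open, on these data alone, is whether an unsubstituted phenyl or a pyridine ring would behave the same way on this carbonyl carbon. As far as these compounds go, the same exchange alongside the trifluoromethyl group of compound 1 also remains untested here.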